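Pyridin-2-yl in place of 4-methoxyphenyl on the shared core

The source may report more compounds than this note shows. Statements on the series, on what has been measured and on what is new or still open speak of the compounds shown alone.

In an ADME assay on Vero cells (Chlorocebus sabaeus) for cytotoxicity, read by MTT assay, with a stated time of 96 h (on this read-out lower numbers stand for higher toxicity in this test and higher numbers for lower toxicity in this test), the readings for this series are thin. Compound 1 `C/C(=N\NC(N)=O)c1ccc2c(c1)nc(-c1ccc(Cl)cc1)n2C1CCCCC1` gives > 100000 nM as a limit and not a number. Compound 2 `C/C(=N\NC(N)=O)c1ccc2c(c1)nc(-c1ccc(C(F)(F)F)cc1)n2C1CCCCC1` gives > 100000 nM as a limit too. Trifluoromethyl in place of chloro on an aromatic carbon thus yields a step that the two limits leave unreadable from compound 1 to compound 2 and no usable size. Compound 3 `COc1ccc(-c2nc3cc(/C(C)=N/NC(N)=O)ccc3n2C2CCCCC2)cc1` has no single number and stands as "not determined" (no result reported) in this series. The nearest evidence for its standing is the limit of > 100000 nM in this assay, at which 2 of the 3 values shown sit, and no more.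

Compound 4 `C/C(=N\NC(N)=O)c1ccc2c(c1)nc(-c1ccccn1)n2C1CCCCC1` differs from compound 3 by pyridin-2-yl in place of 4-methoxyphenyl on an aromatic carbon and so carries pyridin-2-yl in place of 4-methoxyphenyl on an aromatic carbon. Only a step that the two limits leave unreadable from compound 1 to compound 2 bears on this change, and only loosely. For the measured compounds named here, no step of readable size and no direction can be expected in this assay because the limit of > 100000 nM in this assay, at which 2 of the 3 values shown sit, is all that compound 1 and compound 2 offer. The estimate for compound 4 is 100000 nM with an expected range from 40000 nM to 250000 nM and most likely a limit again.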

Compound 4, half-maximal cytotoxic concentration: > 100000 nM
Compound 4: only a limit was reported; the forecaster's own chance of this, stated with the estimate: 75%; the middle value lies on the limit itself.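

No new step can be read in this assay: compound 1, compound 2 and compound 4 each give only a limit, and the steps among them cannot be read. The compounds shown leave open whether any group at this place on the shared core changes the half-maximal cytotoxic concentration, as the only evidence is: the limit of > 100000 nM in this assay, at which 3 of the 4 values shown sit.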